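The compounds below may be only part of what the source reports. "The series", "measured", "known", "first", "only" and "open" are said of these compounds alone.

Working notes on the series in a functional assay, with a stated time of 10 min; on this read-out higher numbers stand for weaker inhibition and lower numbers for stronger inhibition. Compound 3 `CCCCCCCCCCOc1cc(OC)ccc1C(C)=O` gives 57400000 nM and sits within the scatter of compound 2 `CCCCCCOc1cc(OC)ccc1C(C)=O` at 84400000 nM. Compound 1 `CCCCCCCCCCCCOc1cc(OC)c(Br)cc1C(C)=O` gives 23100000 nM, a lower number than compound 3 and beyond the scatter. For the measured compounds named here, compound 1 differs from compound 3 in more than one place, so it offers no single-change step to draw on here.

Compound 4 `CCCCCCCCCCCCOc1cc(OC)ccc1C(C)=O` extends the chain of compound 3 by one further change: ethyl in place of hydrogen on a saturated chain carbon, ten or more bonds along the chain from an oxygen on an aromatic ring. Going by the values given here, only one measured step bears on this, a change on the same chain: a 1.5-fold lower number from compound 2 to compound 3 (0.17 log units; within the scatter). That step added butyl and stayed within the scatter. Ethyl is the smaller addition, so no shift beyond the scatter is expected in this assay, though a slight drift to a lower number would fit the one step available. The expected change is a 1.2-fold lower number from compound 3 to compound 4 (0.08 log units; within the scatter), which is within the scatter. For compound 4 the estimated value is 48000000 nM, with an expected range from 24000000 nM to 96000000 nM.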

Compound 4, half-maximal inhibitory concentration: 65600000 nM
Estimate against measurement, compound 4: 1.4-fold (0.14 log units) below; measured number inside the range.
By their numbers in this assay, from the lowest: compound 1; then compounds 3, 4 and 2 (each within the scatter of the next).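

In this assay, for the compounds shown here, ethyl at this far chain position gives a 1.1-fold higher number from compound 3 to compound 4 (0.06 log units; within the scatter) and the larger hexyl addition gives a 1.3-fold lower number from compound 2 to compound 4 (0.11 log units; within the scatter) so neither addition moves the number beyond the scatter, and the one earlier chain step is no longer alone in showing this. Going by these compounds alone, the first single change to clear the scatter lies on the aromatic carbon and not on the chain: hydrogen in place of bromo gives a 2.8-fold higher number from compound 1 to compound 4 (0.45 log units; beyond the scatter) and this shows that, with the chain held constant, the bromo group goes with the lower number. No supporting measurement is available to explain either the flat chain steps or the bromo step.

From the compounds shown here alone, whether a longer chain, or an amine or a carboxylic acid at the end of the chain, would shift the number beyond the scatter stays open. Also open, going by these compounds, is whether bromo gives a similar step on the shorter chains of compound 2 and compound 3.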